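Toxicity shift on moving from a benzyl to a phenylethyl amine

The source may hold more compounds than are shown below. What is called first, only, known or untested is meant among the compounds shown, and "the series" means these compounds.

Compound 1 `Cc1nc(N(C)C)nc(N[C@@H]2C[C@H](CO)[C@@H](O)[C@H]2O)c1-c1nc2cnccc2s1`: 25000 nM
Compound 2 `Cc1nc(NCc2c(F)cccc2F)nc(N[C@@H]2C[C@H](CO)[C@@H](O)[C@H]2O)c1-c1nc2cnccc2s1`: 4000 nM

In an ADME assay on cells (Homo sapiens) for cytotoxicity, read by polymerase chain reaction, with a stated time of 3 days (on this read-out lower numbers stand for higher toxicity in this test and higher numbers for lower toxicity in this test), compound 2 holds the lower of the two numbers, and the step of a 6.3-fold lower number from compound 1 to compound 2 (0.80 log units; beyond the scatter) lies beyond the scatter. Compound 3 `Cc1nc(N[C@H](C)c2ccc(F)cc2)nc(N[C@@H]2C[C@H](CO)[C@@H](O)[C@H]2O)c1-c1nc2cnccc2s1` is not yet measured. It differs from compound 2 by 1-(4-fluorophenyl)ethyl in place of 2,6-difluorobenzyl on a nitrogen on an aromatic ring. Within the data shown here, the only measured step, a 6.3-fold lower number from compound 1 to compound 2 (0.80 log units; beyond the scatter), concerns the same nitrogen but swaps dimethylamino for the benzyl group, so it bears only loosely on the present change. With both groups of like size, compound 3 is expected to show a step of no change at the digits printed from compound 2 to compound 3 (within the scatter), within the scatter. Compound 3 is estimated at 4000 nM, between 1500 nM and 11000 nM.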

Compound 3, half-maximal cytotoxic concentration: 25000 nM
For compound 3 the middle estimate is 6.3-fold (0.80 log units) below the measured one; measured number above the stated range.
By their numbers in this assay, from the lowest: compound 2; then compounds 1 and 3 (each within the scatter of the next).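

In this assay the change on the nitrogen gives a 6.3-fold higher number from compound 2 to compound 3 (0.80 log units; beyond the scatter), so two groups of equal heavy-atom count are not interchangeable at this position. The further step shows no change at the digits printed from compound 1 to compound 3 (within the scatter), which leaves compound 2 alone apart from the other two and means that an aromatic ring on this nitrogen does not by itself bring the lower number. No measurement on hand bears on the reason for this. From the compounds shown here alone, whether the step follows the fluorine pattern, the added methyl or the defined stereocentre stays open. Going by these compounds, how an unsubstituted benzylamine or a morpholine would read at this position also stays open.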